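The source may hold more compounds than are shown below. What is called first, only, known or untested is meant among the compounds shown, and "the series" means these compounds.

Compound 1 `CCCCCC(=O)Nc1ccc(S(=O)(=O)Oc2ccccc2C(C)C)cc1` gives 6300 nM in a functional assay on HT-1080 cells (Homo sapiens) for antiproliferative activity, read by sulforhodamine B assay, with a stated time of 48 h; on this read-out higher numbers stand for weaker inhibition and lower numbers for stronger inhibition.
Compound 2 `CC(C)c1ccccc1OS(=O)(=O)c1ccc(NC(=O)CCCCl)cc1` gives 3800 nM in this assay.
Compound 3 `CCNC(=O)Nc1ccc(S(=O)(=O)Oc2ccccc2C(C)C)cc1` gives 250 nM in this assay.

Compound 3 stands lowest of the three measured numbers, separated from its neighbours by two large steps, a 15-fold lower number from compound 2 to compound 3 (1.18 log units; beyond the scatter) and a 25-fold lower number from compound 1 to compound 3 (1.40 log units; beyond the scatter). Compound 4 `CC(C)c1ccccc1OS(=O)(=O)c1ccc(NC(=O)NCCCCl)cc1` differs from compound 3 by chloromethyl in place of hydrogen on a saturated chain carbon, two bonds along the chain from an amide-type nitrogen. For the measured compounds named here, the only measured step that resembles this change is a 1.7-fold lower number from compound 1 to compound 2 (0.22 log units; within the scatter), where a chlorine-ending chain replaced an all-carbon chain on the amide side and the number barely moved. On that basis no step beyond the scatter is expected from compound 3 to compound 4, so compound 4 is expected near 220 nM, within 80 nM to 600 nM, a change of a 1.1-fold lower number from compound 3 to compound 4 (0.06 log units; within the scatter).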

Compound 4, half-maximal inhibitory concentration: 2700 nM
Beside the measured number, compound 4's estimate is 12-fold (1.09 log units) below it; the measured number lies above the stated range.
By their numbers in this assay, from the lowest: compound 3; then compounds 4, 2 and 1 (each within the scatter of the next, the first and the last beyond it).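

Lengthening the ethylamino group of compound 3 to (3-chloropropyl)amino gives an 11-fold higher number from compound 3 to compound 4 (1.03 log units; beyond the scatter), so at this saturated chain carbon, unlike in the earlier chain change, chloromethyl in place of hydrogen costs much activity. The amino link alone does not bring the activity of compound 3: (3-chloropropyl)amino in place of 3-chloropropyl gives a 1.4-fold lower number from compound 2 to compound 4 (0.15 log units; within the scatter), and in place of pentyl it gives only a 2.3-fold lower number from compound 1 to compound 4 (0.37 log units; beyond the scatter). Nothing measured here explains this loss.

On these data alone, whether the chlorine or the longer chain matters stays open. A propylamino group on the same carbonyl carbon would separate the two.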